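The compounds below may be only part of what the source reports. "The series", "measured", "known", "first", "only" and "open" are said of these compounds alone.

Measured compounds:
- compound 1 `Cc1c(Nc2nc(N)c3c(C#N)c(N4CCC[C@H]4C)n(C)c3n2)cnn1C`: 75 nM
- compound 2 `Cc1nn(C2COC2)cc1Nc1nc(N)c2c(C#N)c(N3CCC[C@H]3C)n(C)c2n1`: 38 nM
- compound 3 `C[C@@H]1CCCN1c1c(C#N)c2c(N)ncnc2n1C`: 15 nM

In an assay on isolated protein for inhibition of Leucine-rich repeat serine/threonine-protein kinase 2 (Homo sapiens), read by TR-FRET and LanthaScreen, with stated times of 50 min and 30 min, in the presence of a further agent that is not named here (a lower number here means a stronger inhibitor, a higher number a weaker inhibitor), compound 3 has the lowest number of the three, with compound 2 the nearest. Compound 4 `C[C@@H]1CCCN1c1c(C#N)c2c(N)nc(Nc3cnn(C)c3)nc2n1C` differs from compound 3 by (1-methyl-1H-pyrazol-4-yl)amino in place of hydrogen on an aromatic carbon. The step that bears on this is the reverse kind: going from compound 1 to compound 3 removed a pyrazolylamino group from the same position and gave a 5.0-fold lower number from compound 1 to compound 3 (0.70 log units; beyond the scatter); compound 2, carrying another such group, sits at 38 nM. Putting a pyrazolylamino group back is therefore expected to raise the number modestly, roughly a 3.0-fold higher number from compound 3 to compound 4 (0.48 log units; beyond the scatter). Compound 4 is estimated at 45 nM, within a range of 15 nM to 150 nM.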

Compound 4, half-maximal inhibitory concentration: 6 nM
Beside the measured number, compound 4's estimate is 7.5-fold (0.88 log units) above it, and the stated range ends above it.
By their numbers in this assay, from the lowest: compound 4; then compound 3; then compounds 2 and 1 (each within the scatter of the next).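

In this assay, the aromatic carbon between two ring nitrogen atoms can gain from a pyrazolylamino group: adding (1-methyl-1H-pyrazol-4-yl)amino gives a 2.5-fold lower number from compound 3 to compound 4 (0.40 log units; beyond the scatter), whereas removing the dimethyl version gave a 5.0-fold lower number from compound 1 to compound 3 (0.70 log units; beyond the scatter). The outcome therefore depends on the groups on the pyrazole: hydrogen in place of methyl on its aromatic carbon gives a 13-fold lower number from compound 1 to compound 4 (1.10 log units; beyond the scatter), and 1-methyl-1H-pyrazol-4-yl in place of the oxetanyl pyrazole gives a 6.3-fold lower number from compound 2 to compound 4 (0.80 log units; beyond the scatter). No evidence here explains these differences. Still open, going by these compounds, is whether a 2-hydroxyethyl chain or a piperidin-4-yl ring on the pyrazole nitrogen would keep this gain.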